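A Second Fluoro Group on Compound 3

This account rests on a few compounds, and the source may have more. Where it says the series, first, only, none or still open, it means among the compounds named here.

Of the compounds shown here, three have so far been measured in an ADME assay on the whole organism (Rattus norvegicus, strain Sprague-Dawley) for pharmacokinetics, using cassette dosing, at a dose of 1 mg/kg by the oral route; a lower number here means that a smaller share of the oral dose reaches the circulation, a higher number that a larger share of the oral dose reaches the circulation. Compound 1 `O=C(c1cc(-c2cn[nH]c2)on1)N1CCC(Cc2ccc(Cl)cc2)CC1` gives 0.6%, compound 2 `O=C(c1cc(-c2ccc(=O)[nH]c2)on1)N1CCC(Cc2ccc(F)cc2)CC1` gives 18.4%, and compound 3 `O=C(Nc1ccc2[nH]c(=O)oc2c1)C(=O)N1CCN(c2ccc(F)cc2)CC1` gives 39.3%. Compound 3 therefore stands highest of the three, and its gaps to compound 2 and to compound 1 both lie beyond the usual scatter. No two of these compounds differ in only one place, so the numbers give no direct measure of what a single structural change does.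

Compound 4 `O=C(Nc1ccc2[nH]c(=O)oc2c1)C(=O)N1CCN(c2ccc(F)c(F)c2)CC1` departs from compound 3 at one point: fluoro in place of hydrogen on an aromatic carbon. A fluoro group takes the place of a hydrogen on an aromatic carbon, ortho to a fluoro group and meta to a large group, so that 4-fluorophenyl becomes 3,4-difluorophenyl. The rest of the structure stays the same. Among the measured compounds shown here, the expectation is anchored on compound 3 at 39.3%, and with no measured precedent for this change, the range is kept wide. The expected step is small and slightly downward, a number 3.3 percentage points lower from compound 3 to compound 4 (within the scatter), and is not expected to lie beyond the scatter. The estimate for compound 4 is 36%, with an expected range from 18% to 54%.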

Compound 4, oral bioavailability: 13%
Compound 4: the middle estimate sits 23 percentage points above what was measured, and the stated range ends above it.
By their numbers in this assay, from the lowest: compound 1; then compounds 4 and 2 (each within the scatter of the next); then compound 3.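

Among the compounds shown here, this is the first step in the set that changes one place only, and it shows that this position is not neutral for oral exposure in the rat. In this assay, fluoro in place of hydrogen on an aromatic carbon, ortho to a fluoro group and meta to a large group, gives a number 26.3 percentage points lower from compound 3 to compound 4 (beyond the scatter), even though the change adds no ring, no hydrogen-bond donor, no hydrogen-bond acceptor and no net charge. Nothing at hand bears on the mechanism behind this loss, so the step stands as an observation without an explanation.

The compounds shown leave open whether the loss belongs to fluoro in particular or would also follow from another group at the same place, such as chloro, methyl, methoxy or nitrile. They also leave open whether 3,4-difluorophenyl would have the same effect on another core, since this single step comes from one pair and sets no rule beyond compound 3 and compound 4.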